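Replacing nitro with hydrogen in a thiazolylidene acetohydrazide

The source may report more compounds than this note shows. Statements on the series, on what has been measured and on what is new or still open speak of the compounds shown alone.

Measured compounds:
compound 1, `Cn1nnnc1SCC(=O)N/N=c1/scc(-c2ccccc2)n1-c1ccccc1`, 173 ug/mL
compound 2, `Cn1cnnc1SCC(=O)N/N=c1/scc(-c2ccc([N+](=O)[O-])cc2)n1-c1ccccc1`, 133 ug/mL

In an ADME assay on NIH3T3 cells (Mus musculus) for cytotoxicity, read by MTT assay, with a stated time of 24 h (a higher number here means a weaker inhibitor, a lower number a stronger inhibitor), compound 2 gives the lower of the two numbers recorded so far, but its nearest neighbour, compound 1, lies within the scatter of it, so the two cannot be placed in order. Compound 3, `Cn1cnnc1SCC(=O)N/N=c1/scc(-c2ccccc2)n1-c1ccccc1`, has not yet been measured in this assay. It differs from compound 2 in one place: hydrogen in place of nitro on an aromatic carbon. Among the compounds with values here, no step between measured compounds isolates this change, since compound 1 and compound 2 also differ elsewhere in their structure. With both recorded numbers close together, the step of a 1.1-fold higher number from compound 2 to compound 3 (0.05 log units; within the scatter) is expected to be small, with no direction beyond the scatter. Compound 3 is therefore estimated at 150 ug/mL in this assay, with a range of 75 ug/mL to 300 ug/mL.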

Compound 3, half-maximal inhibitory concentration: 217 ug/mL
Compound 3: the middle estimate sits 1.4-fold (0.16 log units) below what was measured; the measured number falls inside the stated range.
By their numbers in this assay, from the lowest: compounds 2, 1 and 3 (each within the scatter of the next).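

With the 4-nitrophenyl to phenyl change now isolated on a shared core in this assay, the step (a 1.6-fold higher number from compound 2 to compound 3 (0.21 log units; within the scatter)) can be read directly, and at this place on the six-membered aromatic ring, hydrogen in place of nitro stays within the scatter. The second single change, 4-methyl-4H-1,2,4-triazol-3-yl in place of 1-methyl-1H-tetrazol-5-yl on the sulfur (a 1.3-fold higher number from compound 1 to compound 3 (0.10 log units; within the scatter)), also stays within the scatter, so across these three compounds neither change can be told apart from repeat measurement. Nothing available explains either step or speaks to what lies behind these numbers.

As far as these compounds go, whether an amine, a carboxylic acid or a methoxy group at this same place would give a step beyond the scatter remains open. So does whether the 4-nitrophenyl to phenyl change reads the same with 1-methyl-1H-tetrazol-5-yl on the sulfur.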